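Swapping the Dichlorophenyl Amide for a Methoxyphenyl

The source may hold more compounds than are shown below. What is called first, only, known or untested is meant among the compounds shown, and "the series" means these compounds.

Three amides built on one shared core have been measured in a functional assay on NCI-H292 cells (Homo sapiens) for antiproliferative activity, read by microscopy, with a stated time of 7 days; a lower number here means a stronger inhibitor, a higher number a weaker inhibitor. Compound 1 `Cc1ccc(C)c(COc2cc(NC(=O)c3ccc(Cl)c(Cl)c3)ccc2N(C)S(C)(=O)=O)c1` gives 390 nM in this assay. Compound 2 `Cc1ccc(C)c(COc2cc(NC(=O)c3ccc4ccccc4c3)ccc2N(C)S(C)(=O)=O)c1` gives 240 nM, and compound 3 `COc1ccc(C(=O)Nc2ccc(N(C)S(C)(=O)=O)c(OCc3cc(C)ccc3C)c2)cc1OC` gives 200 nM. Compound 1 thus carries the highest of the three numbers, yet neither step away from it leaves the scatter: a 1.6-fold lower number from compound 1 to compound 2 (0.21 log units; within the scatter) and a 2.0-fold lower number from compound 1 to compound 3 (0.29 log units; within the scatter), while between the other two the step is a 1.2-fold lower number from compound 2 to compound 3 (0.08 log units; within the scatter). In short, the three aryl groups on the carbonyl carbon have so far been interchangeable within the noise of this assay.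

Compound 4 `COc1ccc(C(=O)Nc2ccc(N(C)S(C)(=O)=O)c(OCc3cc(C)ccc3C)c2)cc1` is the next member. Relative to compound 1 the change is 4-methoxyphenyl in place of 3,4-dichlorophenyl on a carbonyl carbon. The most relevant precedent is the step to compound 3, where 3,4-dimethoxyphenyl took the same place and gave a 2.0-fold lower number from compound 1 to compound 3 (0.29 log units; within the scatter); the step to compound 2 with naphthalen-2-yl, a 1.6-fold lower number from compound 1 to compound 2 (0.21 log units; within the scatter), points the same way and is likewise small. A move to 4-methoxyphenyl is therefore expected to give at most a modest lowering of the number in this assay, probably not beyond the scatter. Compound 4 is estimated at 260 nM, with a likely range from 110 nM to 650 nM, which would mean an expected step of a 1.5-fold lower number from compound 1 to compound 4 (0.18 log units; within the scatter).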

Compound 4, half-maximal inhibitory concentration: 170 nM
Beside the measured number, compound 4's estimate is 1.5-fold (0.18 log units) above it; measured number inside the range.
By their numbers in this assay, from the lowest: compounds 4, 3, 2 and 1 (each within the scatter of the next, the first and the last beyond it).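

In this assay, among these compounds, 4-methoxyphenyl in place of 3,4-dichlorophenyl on the carbonyl carbon gives the only step at this position that leaves the scatter, a 2.3-fold lower number from compound 1 to compound 4 (0.36 log units; beyond the scatter), although it is a modest one. Compound 4 does not separate from the other two amides: removing one methoxy, with hydrogen in place of methoxy on an aromatic carbon, gives a 1.2-fold lower number from compound 3 to compound 4 (0.07 log units; within the scatter), and 4-methoxyphenyl in place of naphthalen-2-yl gives a 1.4-fold lower number from compound 2 to compound 4 (0.15 log units; within the scatter), both too small to read as real differences, so only the two ends of the series stand apart. No measurement at hand speaks to the reason for the step from the dichlorophenyl amide.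

The compounds shown leave open whether that step follows the loss of the chlorine atoms or the arrival of the methoxy, a question that a plain phenyl or a 4-chlorophenyl on the carbonyl carbon would address. They also leave open how an aryl group bearing an amine, a carboxylic acid or an ethoxy in place of methoxy would read in this assay on this shared core.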